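A few compounds are considered here, and "the series" means these few. Any claim that something is new, unique, unknown or untested is made for them only; others in the source may bear on it.

Measured in an ADME assay on HEK293 cells (Homo sapiens) for cytotoxicity, read by resazurin assay, with a stated time of 72 h; a higher number here means that more compound is tolerated, a lower number that less compound is tolerated:
- compound 1 `CCc1cccc(CNC(=O)c2nc3ccc(F)c(COc4ccc(CC(=O)O)cc4)c3c(=O)[nH]2)c1`: > 20000 nM
- compound 2 `CCc1cccc(CNC(=O)c2nc3ccc(F)c(COCc4ccc(C(=O)O)cc4)c3c(=O)[nH]2)c1`: > 20000 nM

Compound 1 has no number, only a limit of the assay: > 20000 nM. Compound 2 also gives only a limit: > 20000 nM. For the measured compounds named here, the one measured step, a step that the two limits leave unreadable from compound 1 to compound 2, puts 4-carboxybenzyl in place of 4-(carboxymethyl)phenyl on an oxygen on a saturated carbon, and it gives no size to work from.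

Compound 3 `CCc1cccc(CNC(=O)c2nc3cccc(COc4ccc(CC(=O)O)cc4)c3c(=O)[nH]2)c1` differs from compound 1 in one place, hydrogen in place of fluoro on an aromatic carbon. Going by the values given here, no measured step covers this change, so the only guide is the limit of > 20000 nM in this assay, at which 2 of the 2 values shown sit, shared by compound 1 and compound 2. In this assay, the expected step that the limit leaves unreadable from compound 1 to compound 3 is none beyond the scatter, and a further limit is the likeliest report. Compound 3 is estimated at 25000 nM, with an expected range of 10000 nM to 50000 nM.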

Compound 3, half-maximal cytotoxic concentration: > 20000 nM
Compound 3 gave a limit, no number; the forecaster's own chance of this, stated with the estimate: 85%; the middle value lies beyond the limit too.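

In this assay, compound 1 and compound 3 both give only a limit of the assay, so no step can be read between them. The compounds shown leave open how far the tolerated concentration of compound 1, compound 2 and compound 3 lies past that limit, and whether exchanging fluoro for hydrogen changes it.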